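A New Ring on the Sulfonyl Sulfur

A few compounds are considered here, and "the series" means these few. Any claim that something is new, unique, unknown or untested is made for them only; others in the source may bear on it.

In an ADME assay on microsomes from liver (Homo sapiens) for metabolic stability, read by LC-MS, using NADPH, with a stated time of 30 min, tested at 0.1 uM (a lower number here means that less of the compound is left, a higher number that more of the compound is left), compound 1 `O=S(=O)(c1cccc(-c2ccc3nccc(-c4ccncc4)c3n2)c1)N1CCC(O)CC1` gives 5%, and compound 2 `O=S(=O)(c1cccc(-c2ccc3nccc(-c4ccncc4)c3n2)c1)N1CC[C@H](O)C1` gives 17%, the higher of the two numbers. Compound 3 `C[C@@H]1CN(S(=O)(=O)c2cccc(-c3ccc4nccc(-c5ccncc5)c4n3)c2)C[C@H](C)N1` carries 3,5-dimethylpiperazin-1-yl in place of the 3-hydroxypyrrolidin-1-yl of compound 2 on a sulfonyl sulfur: 3,5-dimethylpiperazin-1-yl in place of 3-hydroxypyrrolidin-1-yl on a sulfonyl sulfur. Going by the values given here, the one measured step that bears on this also swaps the group on a sulfonyl sulfur: a number 12 percentage points higher from compound 1 to compound 2 (beyond the scatter), a modest change. Among the compounds with values here, with only that step as a guide, a small upward move is expected, with none beyond the scatter: a number 5 percentage points higher from compound 2 to compound 3 (within the scatter). The estimate for compound 3 is 22%, with an expected range from 6% to 50%.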

Compound 3, percent of the compound remaining in the Homo sapiens assay: 34%
Beside the measured number, compound 3's estimate is 12 percentage points below it, within the range that was stated.
By their numbers in the Homo sapiens assay, from the lowest: compound 1; then compound 2; then compound 3.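

Groups other than hydroxy-bearing rings now have a reading on the sulfonyl sulfur: in the Homo sapiens assay there is a number 17 percentage points higher from compound 2 to compound 3 (beyond the scatter), and a number 29 percentage points higher from compound 1 to compound 3 (beyond the scatter). Ring size alone does not order these numbers, since the six-membered rings of compound 1 and compound 3 stand at the two ends of the three. The same change also moves a physicochemical assay for solubility, read by HPLC, using the shake flask method, measured as kinetic solubility, with a stated time of 20 h, at pH 6.5, tested at 200 uM (a lower number here means a less soluble compound, a higher number a more soluble compound), where compound 2 gives 20000 nM and compound 3 gives 180000 nM: the measured solubility of compound 2, 20000 nM, and of compound 3, 180000 nM, a 9.0-fold higher number (0.95 log units; beyond the scatter)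

The compounds shown leave open whether the two methyl groups or the second ring nitrogen accounts for these steps. As far as these compounds go, how an unsubstituted piperazine or a morpholine on the sulfonyl sulfur would read in either assay also stays open.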